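Swapping fluoro for chloro on a cinnamoyl sulfonamide

The compounds below may be only part of what the source reports. "The series", "measured", "known", "first", "only" and "open" are said of these compounds alone.

Compound 1 `O=C(/C=C/c1ccccc1)NS(=O)(=O)c1ccc(F)cc1`: 2.1 ug/mL
Compound 2 `O=C(/C=C/c1ccccc1)NS(=O)(=O)c1ccc(Cl)cc1`: 2.2 ug/mL
Compound 3 `O=C(/C=C/c1ccc(F)cc1)NS(=O)(=O)c1ccc(F)cc1`: 0.8 ug/mL

These three compounds were tested in a functional assay on B16-F10 cells (Mus musculus) for antiproliferative activity, read by ELISA and MTT assay, with a stated time of 48 h; on this read-out lower numbers stand for stronger inhibition and higher numbers for weaker inhibition. Compound 2 differs from compound 1 by chloro in place of fluoro on an aromatic carbon, and that change made a 1.0-fold higher number from compound 1 to compound 2 (0.02 log units; within the scatter). Compound 3 differs from compound 1 by fluoro in place of hydrogen on an aromatic carbon, with a step of a 2.6-fold lower number from compound 1 to compound 3 (0.42 log units; beyond the scatter); this same difference is also what separates the core of compound 3 and compound 4 from the core of compound 1 and compound 2.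

Compound 4 `O=C(/C=C/c1ccc(F)cc1)NS(=O)(=O)c1ccc(Cl)cc1` has not yet been measured in this assay. It differs from compound 3 by chloro in place of fluoro on an aromatic carbon. The place of this change is the same as in the change from compound 1 to compound 2, word for word, so it is the same change made on the other core.

Among the measured compounds shown here, because the single earlier instance of this change gave a 1.0-fold higher number from compound 1 to compound 2 (0.02 log units; within the scatter), the step from compound 3 to compound 4 is expected to be about a 1.1-fold higher number from compound 3 to compound 4 (0.03 log units; within the scatter), a step that rests on one pair only. Compound 4 is therefore estimated to give about 0.85 ug/mL in this assay, most likely between 0.4 ug/mL and 1.8 ug/mL.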

Compound 4, half-maximal inhibitory concentration: 2.6 ug/mL
The estimate for compound 4 lay 3.1-fold (0.49 log units) below the measured number; the whole stated range lies below it.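

In this assay, the swap of fluoro for chloro did not carry over from one core to the other, and the new step is a 3.3-fold higher number from compound 3 to compound 4 (0.51 log units; beyond the scatter); set beside the earlier one, the two differ: the same change on two cores in this assay, a 1.0-fold higher number (0.02 log units; within the scatter) from compound 1 to compound 2 and a 3.3-fold higher number (0.51 log units; beyond the scatter) from compound 3 to compound 4, 3.1-fold (0.49 log units) apart, beyond the scatter of two such steps. Fluoro in place of hydrogen failed to carry over as well, giving a 1.2-fold higher number from compound 2 to compound 4 (0.07 log units; within the scatter) on the chloro-bearing side: the same change on two cores in this assay, a 2.6-fold lower number (0.42 log units; beyond the scatter) from compound 1 to compound 3 and a 1.2-fold higher number (0.07 log units; within the scatter) from compound 2 to compound 4, 3.1-fold (0.49 log units) apart, beyond the scatter of two such steps. So in these four compounds the effect of one change depended on what stood on the other ring, but a single set of four cannot show why this happens or whether it holds beyond them.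

What remains open is whether the gain seen in compound 3 needs fluoro on both rings or would also appear with other pairs of groups, such as bromo, methyl or methoxy. On these data alone, it is also open whether a similar dependence would be seen with a methyl group in place of the amide hydrogen.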